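Triazole substituent swap on the oxadiazole-linked sulfonamide series

A few compounds are considered here, and "the series" means these few. Any claim that something is new, unique, unknown or untested is made for them only; others in the source may bear on it.

Three compounds share a chlorinated benzenesulfonamide core carrying an oxadiazole with a methylene-linked substituent. Compound 1 `NS(=O)(=O)c1cc(-c2nnc(CN3CCN(Cc4ccccc4)CC3)o2)c(Cl)cc1SCc1ccccc1` is the strongest of the three in a functional assay on HeLa cells (Homo sapiens) for cytotoxicity, read by MTT assay, with a stated time of 72 h (a higher number here means a weaker inhibitor, a lower number a stronger inhibitor), where compound 1 gives 17000 nM. Compound 2 `[N-]=[N+]=NCc1nnc(-c2cc(S(N)(=O)=O)c(SCc3ccccc3)cc2Cl)o1` gives 115000 nM in this assay, and compound 3 `CCOC(=O)c1cn(Cc2nnc(-c3cc(S(N)(=O)=O)c(SCc4ccccc4)cc3Cl)o2)nn1` gives 122000 nM, the highest number of the three; the gap to compound 2 is within the scatter, so no order between them can be read, while compound 1 sits well below both.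

For the measured compounds named here, the only single-point step recorded, a 1.1-fold higher number from compound 2 to compound 3 (0.03 log units; within the scatter), shows that closing the azide into the ester-bearing triazole left the number essentially unchanged.

Compound 4 `NS(=O)(=O)c1cc(-c2nnc(Cn3cc(-c4ccccc4)nn3)o2)c(Cl)cc1SCc1ccccc1` differs from compound 3 as follows: phenyl in place of ethoxycarbonyl on an aromatic carbon. Going by the values given here, no measured step covers this particular exchange on the triazole. Among the compounds with values here, the one step available was flat, so a further exchange at the same ring is expected to give at most a modest movement, a 1.7-fold lower number from compound 3 to compound 4 (0.24 log units; within the scatter), towards a lower number. Compound 4 is therefore estimated at 70000 nM, with a range from 25000 nM to 200000 nM.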

Compound 4, half-maximal inhibitory concentration: 7000 nM
The estimate for compound 4 lay 10-fold (1.00 log units) above the measured number; measured number below the stated range.
By their numbers in this assay, from the lowest: compound 4; then compound 1; then compounds 2 and 3 (each within the scatter of the next).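

In this assay, the substituent on the triazole carbon proves decisive: phenyl in place of ethoxycarbonyl gives a 17-fold lower number from compound 3 to compound 4 (1.24 log units; beyond the scatter), so the flat a 1.1-fold higher number from compound 2 to compound 3 (0.03 log units; within the scatter) did not show that this end of the molecule is insensitive to change. The triazole alone does not account for the drop, since 4-phenyl-1H-1,2,3-triazol-1-yl in place of azido gives a 16-fold lower number from compound 2 to compound 4 (1.22 log units; beyond the scatter), whereas the ester-bearing triazole stays within the scatter of the azide. Nothing available gives a reason for the effect of the phenyl group.

These compounds leave open whether the aromatic ring itself is what matters, as a cyclohexyl or a butyl group at the same carbon would test. They also do not show how a substituted phenyl, a pyridyl ring or a carboxylic acid would read at this position.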